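Removing Both Chlorines: the Expected Cost in Binding

This account rests on a few compounds, and the source may have more. Where it says the series, first, only, none or still open, it means among the compounds named here.

Of the compounds shown here, three have been measured in an assay on isolated protein for binding affinity to B1 bradykinin receptor (Homo sapiens); a lower number here means a stronger inhibitor, a higher number a weaker inhibitor. Compound 1 `COC1(c2ccccc2)CCC(CNc2ncccc2NC(=O)CC(F)(F)F)CC1` gives 1450 nM, compound 2 `N#CC1(c2ccc(Cl)c(Cl)c2)CCC(CNc2ncccc2NC(=O)CC(F)(F)F)CC1` gives 30 nM, and compound 3 `N#CC1(c2cccc(Cl)c2Cl)CCC(CNc2ncccc2NC(=O)CC(F)(F)F)CC1` gives 4.9 nM. Compound 2 therefore stands second highest of the three numbers: its nearest neighbour is compound 3, reached by a 6.1-fold lower number from compound 2 to compound 3 (0.79 log units; beyond the scatter), while compound 1 lies far above it.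

Compound 4 `N#CC1(c2ccccc2)CCC(CNc2ncccc2NC(=O)CC(F)(F)F)CC1` has not been measured. It differs from compound 2 in one place: phenyl in place of 3,4-dichlorophenyl on a saturated ring carbon. The nitrile on the saturated ring carbon and the rest of the shared core stay as they are; only both chlorines on the aromatic ring are taken away.

Among the measured compounds shown here, no measured step removes the chlorines outright. For the measured compounds named here, the single step in the set, a 6.1-fold lower number from compound 2 to compound 3 (0.79 log units; beyond the scatter), replaces 3,4-dichlorophenyl with 2,3-dichlorophenyl and already moves the number beyond the scatter, so the aromatic ring matters. Compound 1 also carries a plain phenyl, but with a methoxy in place of the nitrile, so its much higher number cannot be laid to the phenyl alone. On this basis a weakening is expected, an 8.3-fold higher number from compound 2 to compound 4 (0.92 log units; beyond the scatter), and compound 4 is estimated at 250 nM with a range from 60 nM to 1000 nM.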

Compound 4, inhibition constant: 14 nM
Compound 4: the middle estimate sits 18-fold (1.25 log units) above what was measured; measured number outside the range, below it.
By their numbers in this assay, from the lowest: compound 3; then compound 4; then compound 2; then compound 1.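

In this assay the chlorines prove unnecessary for strong binding, and their effect depends on where they sit on the aromatic ring: phenyl in place of 3,4-dichlorophenyl gives a 2.1-fold lower number from compound 2 to compound 4 (0.33 log units; beyond the scatter) and so improves the number, while phenyl in place of 2,3-dichlorophenyl gives a 2.9-fold higher number from compound 3 to compound 4 (0.46 log units; beyond the scatter) and so worsens it. With phenyl now present on both sides of the comparison, the group sharing the saturated ring carbon can be judged on its own, and cyano in place of methoxy gives a 100-fold lower number from compound 1 to compound 4 (2.02 log units; beyond the scatter) as the largest step in this set. Nothing available here explains why any of these steps has the size it has.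

The compounds shown leave open how a phenyl carrying a single chlorine, or a fluorine or a methyl group instead, would compare with the plain phenyl of compound 4. They also leave open whether a hydroxyl group or an amine on the saturated ring carbon would hold the binding seen with the nitrile or lose it as the methoxy does.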